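This account rests on a few compounds, and the source may have more. Where it says the series, first, only, none or still open, it means among the compounds named here.

Compound 1, `COc1ccc(/C=C/C(=O)Nc2nnc(-c3ccc(Br)cc3)s2)cc1`, is the cinnamamide of the shared core bearing a methoxy group on the styryl ring and a bromo group on the aryl ring attached to the core. In a functional assay on MCF7 cells (Homo sapiens) for antiproliferative activity, read by MTT assay, with a stated time of 48 h (on this read-out lower numbers stand for stronger inhibition and higher numbers for weaker inhibition), compound 1 gives 1.13 ug/mL, the lowest of the three numbers recorded, though it lies within the scatter of both its neighbours. Compound 2, `O=C(/C=C/c1ccccc1)Nc1nnc(-c2ccc(Br)cc2)s1`, gives 1.5 ug/mL, and compound 3, `O=C(/C=C/c1ccc(C(F)(F)F)cc1)Nc1nnc(-c2ccc(Br)cc2)s1`, gives 1.58 ug/mL. The three measured steps, a 1.3-fold higher number from compound 1 to compound 2 (0.12 log units; within the scatter), a 1.4-fold higher number from compound 1 to compound 3 (0.15 log units; within the scatter) and a 1.1-fold higher number from compound 2 to compound 3 (0.02 log units; within the scatter), all concern the styryl ring and all stay within the scatter, so the series has so far been insensitive to the group tested there.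

Compound 4, `COc1ccc(/C=C/C(=O)Nc2nnc(-c3ccccc3)s2)cc1`, differs from compound 1 at the other ring: hydrogen in place of bromo on an aromatic carbon. Going by the values given here, none of the measured steps touches this position, so they offer no direct guide to the size or direction of the change. With the series showing little response to aromatic substitution so far, compound 4 is expected to land near compound 1, at most a modest rise in the number, a 1.8-fold higher number from compound 1 to compound 4 (0.25 log units; within the scatter). The estimate for compound 4 is 2 ug/mL, with a range from 0.8 ug/mL to 5 ug/mL.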

Compound 4, half-maximal inhibitory concentration: 0.83 ug/mL
Compound 4: the middle estimate sits 2.4-fold (0.38 log units) above what was measured; measured number inside the range.
By their numbers in this assay, from the lowest: compounds 4, 1, 2 and 3 (each within the scatter of the next).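

In this assay, the 4-bromophenyl to phenyl change, the first tested on the aryl ring of the core, gives a 1.4-fold lower number from compound 1 to compound 4 (0.13 log units; within the scatter) with the methoxy group held in place on the styryl ring. This shows that the bromine, para to a large group, can be exchanged for hydrogen without a step beyond the scatter, so this position has so far proved as insensitive as the styryl ring. Nothing shown here offers an explanation for this result.

On these data alone, whether the position would respond to another group, such as an amine, a carboxylic acid or a longer chain, remains open. As far as these compounds go, it is also open whether the same exchange of bromo for hydrogen would read alike with the styryl rings of compound 2 and compound 3.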